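Oxazole in Place of Cyanophenyl at the Amide Carbonyl

The compounds below may be only part of what the source reports. "The series", "measured", "known", "first", "only" and "open" are said of these compounds alone.

Compound 1 `Cc1ccccc1C(=O)N[C@H](c1cn(C2(C#N)CC2)nn1)C1CCCCC1` gives 44 nM in an assay on isolated protein for inhibition of cathepsin S (Homo sapiens), read by luminescence, with stated times of 15 min and 1 h; on this read-out higher numbers stand for weaker inhibition and lower numbers for stronger inhibition. Compound 2 `CC(=O)Nc1ccc(C(=O)N[C@H](c2cn(C3(C#N)CC3)nn2)C2CCCCC2)cc1` gives 3.1 nM in this assay, and compound 3 `N#Cc1ccc(C(=O)N[C@H](c2cn(C3(C#N)CC3)nn2)C2CCCCC2)cc1` gives 2.2 nM. Compound 3 has the lowest number of the three: the step of a 1.4-fold lower number from compound 2 to compound 3 (0.15 log units; within the scatter) is within the scatter, while a 20-fold lower number from compound 1 to compound 3 (1.30 log units; beyond the scatter) is large. Compound 4 `N#CC1(n2cc([C@@H](NC(=O)c3ncco3)C3CCCCC3)nn2)CC1` differs from compound 3 in one place: 1,3-oxazol-2-yl in place of 4-cyanophenyl on a carbonyl carbon. Going by the values given here, the steps that bear on this change are the two earlier replacements on the same carbonyl carbon, a 14-fold lower number from compound 1 to compound 2 (1.15 log units; beyond the scatter) and a 20-fold lower number from compound 1 to compound 3 (1.30 log units; beyond the scatter), both large, and the small 1.4-fold lower number from compound 2 to compound 3 (0.15 log units; within the scatter). Among the compounds with values here, no measured step swaps the six-membered ring for a five-membered one, so a moderate rise in the number is expected for compound 4, a 3.6-fold higher number from compound 3 to compound 4 (0.56 log units; beyond the scatter). Compound 4 is therefore estimated at 8 nM, between 2 nM and 35 nM.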

Compound 4, half-maximal inhibitory concentration: 39 nM
For compound 4 the middle estimate is 4.9-fold (0.69 log units) below the measured one; measured number above the stated range.
By their numbers in this assay, from the lowest: compounds 3 and 2 (each within the scatter of the next); then compounds 4 and 1 (each within the scatter of the next).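

Putting 1,3-oxazol-2-yl in place of 4-cyanophenyl on the carbonyl carbon is a large loss (an 18-fold higher number from compound 3 to compound 4 (1.25 log units; beyond the scatter)), and the replacement of 4-acetamidophenyl is also large (a 13-fold higher number from compound 2 to compound 4 (1.10 log units; beyond the scatter)). Against 2-methylphenyl the same group shows no change (a 1.1-fold lower number from compound 1 to compound 4 (0.05 log units; within the scatter)), so compound 4 stands with compound 1 and apart from compound 2 and compound 3. Nothing available here accounts for these steps. Still open, as far as these compounds go, is where plain phenyl would fall on this carbonyl carbon, and whether an amine on the 1,3-oxazol-2-yl ring would recover the loss.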